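A Small Change on a Ring Nitrogen

The source may report more compounds than this note shows. Statements on the series, on what has been measured and on what is new or still open speak of the compounds shown alone.

Compound 1: `CCCc1nc(-c2ccccc2)c(CNCCCN2CCN(c3ccc(F)cc3)CC2)o1`, 3210 nM
Compound 2: `CCCc1nc(-c2ccccc2)c(CNCCN2CCN(c3ccccc3C)CC2)o1`, 4300 nM

In an assay on HEK293 cells for inhibition of Voltage-dependent T-type calcium channel subunit alpha-1G (Homo sapiens), read by patch clamp (on this read-out lower numbers stand for stronger inhibition and higher numbers for weaker inhibition), compound 1 gives 3210 nM and compound 2 gives 4300 nM; the two numbers sit within the usual scatter of each other, so neither stands apart. Compound 3, `CCCc1nc(-c2ccccc2)c(CNCCCN2CCN(c3ccccc3C)CC2)o1`, is not yet measured. It differs from compound 1 in one place: 2-methylphenyl in place of 4-fluorophenyl on an amine nitrogen in a ring. Among the measured compounds shown here, no measured pair shows this change by itself, so its step size cannot be read off directly. Because compound 2 gives 4300 nM with 2-methylphenyl already in place, the step of a 1.1-fold higher number from compound 1 to compound 3 (0.04 log units; within the scatter) is expected to stay within the scatter. Compound 3 is estimated at 3500 nM, with a range from 1500 nM to 8000 nM.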

Compound 3, half-maximal inhibitory concentration: 8750 nM
For compound 3 the middle estimate is 2.5-fold (0.40 log units) below the measured one, and the stated range ends below it.
By their numbers in this assay, from the lowest: compounds 1 and 2 (each within the scatter of the next); then compound 3.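

In this assay the swap of 2-methylphenyl for 4-fluorophenyl on this ring nitrogen gives a 2.7-fold higher number from compound 1 to compound 3 (0.44 log units; beyond the scatter). Among the compounds shown here, this is the first direct reading of the change, and it shows that the aryl group at this position affects the number, even though both groups hold the same count of heavy atoms. Nothing at hand gives a reason for the step.

For the compounds shown here, the single swap leaves open whether the methyl group, the fluorine or the place of each on the ring drives the step. Unsubstituted phenyl or 4-methylphenyl on the same nitrogen would help to separate these.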